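The source may hold more compounds than are shown below. What is called first, only, known or untested is meant among the compounds shown, and "the series" means these compounds.

Three compounds share one core and differ only in the group attached to its pyridine-type ring. Compound 1 `CC(C(=O)NCc1ccc(C(F)(F)F)nc1NC1CCCCC1)c1ccc(NS(C)(=O)=O)c(F)c1` carries a cyclohexylamino group there, and in a functional assay on CHO-K1 cells for antagonist activity at transient receptor potential cation channel subfamily V member 1 (Homo sapiens), read by FLIPR (a higher number here means a weaker inhibitor, a lower number a stronger inhibitor), compound 1 gives 20.4 nM. Compound 2 `CC1CCC(Nc2nc(C(F)(F)F)ccc2CNC(=O)C(C)c2ccc(NS(C)(=O)=O)c(F)c2)CC1` carries a (4-methylcyclohexyl)amino group, and in this assay compound 2 gives 27.2 nM; the step of a 1.3-fold higher number from compound 1 to compound 2 (0.12 log units; within the scatter) shows that adding the methyl changed little. Compound 3 `CC(C(=O)NCc1ccc(C(F)(F)F)nc1N(C)c1ccccc1)c1ccc(NS(C)(=O)=O)c(F)c1` carries a methyl(phenyl)amino group instead, and in this assay compound 3 gives 0.9 nM, the lowest of the three numbers, set apart from both others by the steps of a 23-fold lower number from compound 1 to compound 3 (1.36 log units; beyond the scatter) and a 30-fold lower number from compound 2 to compound 3 (1.48 log units; beyond the scatter).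

Compound 4 `CC(C(=O)NCc1ccc(C(F)(F)F)nc1N1CCC(C)(C)CC1)c1ccc(NS(C)(=O)=O)c(F)c1` has not yet been measured. It differs from compound 3 in one place: 4,4-dimethylpiperidin-1-yl in place of methyl(phenyl)amino on an aromatic carbon. The entering group is a non-aromatic ring, like the groups of compound 1 and compound 2, while the leaving group held the one aromatic ring that went with the large steps from compound 1 and compound 2 to compound 3. Those two steps bear most directly here, and they suggest that a non-aromatic group at this position gives a clearly higher number. The step of a 17-fold higher number from compound 3 to compound 4 (1.22 log units; beyond the scatter) is therefore expected to be large and upward. For compound 4 in this assay the estimate is 15 nM, with a range from 4 nM to 60 nM.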

Compound 4, inhibition constant: 0.3 nM
Compound 4: the middle estimate sits 50-fold (1.70 log units) above what was measured, outside the stated range (below it).
By their numbers in this assay, from the lowest: compound 4; then compound 3; then compounds 1 and 2 (each within the scatter of the next).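

Compound 4 shows that an aromatic ring is not needed at this position for a low number in this assay, since replacing methyl(phenyl)amino with the non-aromatic 4,4-dimethylpiperidin-1-yl gives a 3.0-fold lower number from compound 3 to compound 4 (0.48 log units; beyond the scatter) rather than a loss. Non-aromatic groups here do not behave alike either: a 68-fold lower number from compound 1 to compound 4 (1.83 log units; beyond the scatter) and a 91-fold lower number from compound 2 to compound 4 (1.96 log units; beyond the scatter) separate this ring from the cyclohexylamino and (4-methylcyclohexyl)amino groups, and what now sets compounds 3 and 4 apart from compounds 1 and 2 is that the nitrogen on the core carries no hydrogen in the first pair but does in the second. No supporting measurement is available to explain these differences.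

Still, the nitrogen hydrogen changes together with the shape of each group across these four compounds, so a methyl(cyclohexyl)amino group, which would keep the cyclohexane ring and remove that hydrogen, would be needed to pull the two apart. Going by these compounds, the part played by the two methyl groups also stays open, and a plain piperidin-1-yl ring or a morpholin-4-yl ring would test how much of the low number depends on them and on an all-carbon ring.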